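The source may report more compounds than this note shows. Statements on the series, on what has been measured and on what is new or still open speak of the compounds shown alone.

In a functional assay on A549 cells (Homo sapiens) for antiproliferative activity, read by MTT assay, with a stated time of 24 h (on this read-out higher numbers stand for weaker inhibition and lower numbers for stronger inhibition), compound 1 `O=C(NNc1ccccc1Cl)c1ccccc1NS(=O)(=O)c1cnc(O)nc1O` gives 5480 nM and compound 2 `O=C(NNc1cccc(Cl)c1)c1ccccc1NS(=O)(=O)c1cnc(O)nc1O` gives 5290 nM as its result. For the measured compounds named here, these two values lie within the usual scatter of each other, so compound 2 stands level with the only other measured compound. Compound 3 `O=C(NNc1ccc(F)cc1)c1ccccc1NS(=O)(=O)c1cnc(O)nc1O` keeps the shared core and carries 4-fluorophenyl in place of 3-chlorophenyl on an amine nitrogen. Going by the values given here, one measured step bears on this change (a 1.0-fold lower number from compound 1 to compound 2 (0.02 log units; within the scatter)), in which one chlorophenyl group replaced another on that same nitrogen. Among the compounds with values here, that step stayed within the scatter, but it is a thin guide, since no measured compound carries a 4-fluorophenyl group and only two values exist so far. No shift beyond the scatter is therefore expected in this assay in either direction. The estimated change is correspondingly small (a 1.0-fold higher number from compound 2 to compound 3 (0.02 log units; within the scatter)). Compound 3 is estimated at 5500 nM on this read-out, with an expected range from 2500 nM to 12000 nM around that figure.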

Compound 3, half-maximal inhibitory concentration: > 20000 nM
Compound 3: no number, only a limit (the forecaster's own chance of this, stated with the estimate: 3%); at least 3.6-fold (0.56 log units) between middle value and limit.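

In this assay compound 3 gives no number, only a limit of the assay, and the new comparisons rest on that single reading: the limit of > 20000 nM in this assay, at which 1 of the 3 values shown sits. Even so, the change to 4-fluorophenyl on this amine nitrogen gives an at least 3.7-fold higher number from compound 2 to compound 3 (0.57 log units; beyond the scatter), and measured against the 2-chlorophenyl compound it gives an at least 3.6-fold higher number from compound 1 to compound 3 (0.56 log units; beyond the scatter). The earlier pair showed no sign of this, as a 1.0-fold lower number from compound 1 to compound 2 (0.02 log units; within the scatter) stayed within the scatter, so this position is not indifferent to the group it carries, at least among these three compounds, and inhibition of the cells weakens with 4-fluorophenyl there.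

The change to compound 3 alters both the halogen and its place on the phenyl ring, so the compounds shown cannot tell which of the two accounts for the loss; a 4-chlorophenyl or a 3-fluorophenyl group on the same nitrogen would separate them. Going by these compounds, how far compound 3 really lies from compound 1 and compound 2 also stays open, as does whether an unsubstituted phenyl or a 4-methoxyphenyl group would keep the activity.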